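Ethyl in place of isopropoxy on the aromatic ring

A few compounds are considered here, and "the series" means these few. Any claim that something is new, unique, unknown or untested is made for them only; others in the source may bear on it.

Measured so far:
compound 1, `CC(C)Oc1ccccc1OC(C)C1=NCCN1`, 100 nM
compound 2, `Cc1cccc(C)c1OC(C)C1=NCCN1`, 27.5 nM

In a functional assay on CHO cells for agonist activity at Alpha-2C adrenergic receptor (Homo sapiens) (on this read-out higher numbers stand for an effect only at larger amounts of compound and lower numbers for an effect already at smaller amounts), compound 1 gives 100 nM, the highest of the two numbers measured. Its nearest neighbour is compound 2, whose 27.5 nM lies beyond the usual scatter of this assay, so compound 1 stands apart as the weaker of the pair.

Compound 3, `CCc1ccccc1OC(C)C1=NCCN1`, has not been measured. It differs from compound 1 in one place: ethyl in place of isopropoxy on an aromatic carbon. The change replaces an ether group with a shorter alkyl group of the kind carried by compound 2, which gave 27.5 nM. Going by the values given here, no measured step connects compound 1 to compound 3, so the size of the change can only be estimated. The step from compound 1 to compound 3 is expected to be a 2.0-fold lower number from compound 1 to compound 3 (0.30 log units; within the scatter), a modest move toward a lower number. Compound 3 is expected to give 50 nM, with a range from 15 nM to 200 nM.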

Compound 3, half-maximal effective concentration: 100 nM
Beside the measured number, compound 3's estimate is 2.0-fold (0.30 log units) below it; low and high end bracket the measured number.
By their numbers in this assay, from the lowest: compound 2; then compounds 1 and 3 (each within the scatter of the next).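

In this assay, putting ethyl in place of isopropoxy on an aromatic carbon gives no change at the digits printed from compound 1 to compound 3 (within the scatter). At this position, then, the read-out does not separate the two groups, even though isopropoxy carries an oxygen and a hydrogen-bond acceptor and ethyl carries neither and has fewer heavy atoms, so neither that oxygen nor the extra size is shown to matter in this pair. No supporting evidence is available that would explain this result.

As far as these compounds go, whether the same holds for groups of a different kind at this carbon, such as an amine, a carboxylic acid or a longer chain, stays open. Compound 2 differs from compound 1 and from compound 3 in more than one place, so the source of its lower number also stays unresolved.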